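A few compounds are considered here, and "the series" means these few. Any claim that something is new, unique, unknown or untested is made for them only; others in the source may bear on it.

This account follows a single change on the shared core. For the measured compounds named here, compound 2 `O=C(/C=C/c1cccc([N+](=O)[O-])c1)c1ccco1` gives 14000 nM in a functional assay on PC-3 cells (Homo sapiens) for inhibition, read by MTT assay, with a stated time of 48 h (on this read-out higher numbers stand for weaker inhibition and lower numbers for stronger inhibition), and that is the lowest of the two numbers known here. Going by the values given here, its only measured neighbour is compound 1 `O=C(/C=C/c1cc([N+](=O)[O-])ccc1Cl)c1ccc[nH]1`, which in this assay gives 55000 nM; the gap between the two values lies beyond the scatter, though no single step links them, as they differ in more than one place.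

Compound 3 `O=C(/C=C/c1cc([N+](=O)[O-])ccc1Cl)c1ccco1` has not yet been measured. Set against compound 2 it shows one change, (chloro in place of hydrogen on an aromatic carbon), that is, chloro in place of hydrogen on an aromatic carbon, ortho to a group of 9 heavy atoms and para to a nitro group.

Among the compounds with values here, no step between measured compounds is available to guide the expectation. Compound 1 carries the same chloro and nitro substitution and gives 55000 nM, so compound 3 is expected to move toward weaker inhibition, a step of a 1.8-fold higher number from compound 2 to compound 3 (0.25 log units; within the scatter) being estimated. For compound 3 the estimated value in this assay is 25000 nM, within a range of 8000 nM to 70000 nM.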

Compound 3, half-maximal inhibitory concentration: 62000 nM
Beside the measured number, compound 3's estimate is 2.5-fold (0.39 log units) below it; measured number inside the range.
By their numbers in this assay, from the lowest: compound 2; then compounds 1 and 3 (each within the scatter of the next).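

In this assay, for the compounds shown here, chloro in place of hydrogen on an aromatic carbon, ortho to a group of 9 heavy atoms and para to a nitro group, gives the first step that can be read at this position: a 4.4-fold higher number from compound 2 to compound 3 (0.65 log units; beyond the scatter) is a modest move toward weaker inhibition, and it lies beyond the scatter. The second single change, furan-2-yl in place of 1H-pyrrol-2-yl on a carbonyl carbon, gives a 1.1-fold higher number from compound 1 to compound 3 (0.05 log units; within the scatter) and lies within the scatter, so with the chloro and nitro groups present these two compounds cannot be told apart in this read-out. Nothing available here accounts for the size of either step.

On these data alone, the chloro step has been read only with the furan-2-yl group on the carbonyl carbon, so it remains open whether the same step would appear with the 1H-pyrrol-2-yl group. As far as these compounds go, it also remains open whether this step belongs to chloro alone or would recur with a fluoro, methyl or methoxy group at the same place, and how an amine in place of the nitro group would read.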